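A few compounds are considered here, and "the series" means these few. Any claim that something is new, unique, unknown or untested is made for them only; others in the source may bear on it.

Compound 2 `C=C1CC[C@@H]2[C@](C)(COC(C)=O)[C@H](OC(C)=O)CC[C@@]2(C)[C@H]1CC(Nc1ccc(S(=O)(=O)Nc2ncccn2)cc1)C1=CCOC1=O` is one of two compounds built on a shared core that have been tested so far, and it is the only one for which a functional assay on MOLT-4 cells (Homo sapiens) for inhibition, read by sulforhodamine B assay, with a stated time of 48 h (on this read-out higher numbers stand for weaker inhibition of growth and lower numbers for stronger inhibition of growth), returns a number: compound 2 gives 8370 nM. Compound 1 `C=C1CC[C@@H]2[C@](C)(COC(C)=O)[C@H](OC(C)=O)CC[C@@]2(C)[C@H]1CC(Nc1ccc(S(=O)(=O)Nc2ccc(Cl)nn2)cc1)C1=CCOC1=O` carries a 6-chloropyridazin-3-yl group on the sulfonamide nitrogen instead. In this assay compound 1 gives > 100000 nM, which is a limit of the assay and not a number. The step of an at least 11-fold lower number from compound 1 to compound 2 (1.07 log units; beyond the scatter) is thus a large one, reckoned against (the limit of > 100000 nM in this assay, at which 1 of the 2 values shown sits). Compound 3 `C=C1CC[C@@H]2[C@](C)(COC(C)=O)[C@H](OC(C)=O)CC[C@@]2(C)[C@H]1CC(Nc1ccc(S(=O)(=O)Nc2nccs2)cc1)C1=CCOC1=O` differs from compound 2 in one place: 1,3-thiazol-2-yl in place of pyrimidin-2-yl on a sulfonamide nitrogen. Among the compounds with values here, the single measured step concerns the same position, the group on the sulfonamide nitrogen, and it was large, so the group at this place can shift the result considerably. In which direction the exchange of pyrimidin-2-yl for 1,3-thiazol-2-yl acts cannot be read from that one step. Compound 3 is therefore expected to give about 10000 nM in this assay, with a range from 3000 nM to 40000 nM. The step of a 1.2-fold higher number from compound 2 to compound 3 (0.08 log units; within the scatter) that this estimate implies is expected to stay within the scatter.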

Compound 3, concentration for total growth inhibition: 73200 nM
Compound 3: the middle estimate sits 7.3-fold (0.86 log units) below what was measured; the measured number lies above the stated range.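

In this assay, within the data shown here, the step of an 8.7-fold higher number from compound 2 to compound 3 (0.94 log units; beyond the scatter) gives the first direction for an exchange between two rings on the sulfonamide nitrogen, and here the change to 1,3-thiazol-2-yl goes towards weaker inhibition of growth. The two groups have equal counts of hydrogen-bond donors and acceptors and neither carries a net charge, so a difference of this size at this position arises with those counts unchanged, and pyrimidin-2-yl is left as the group with the strongest inhibition of growth among the three shown. The step of an at least 1.3-fold lower number from compound 1 to compound 3 (0.13 log units; that floor lies within the scatter) starts from a limit of the assay and not a number, so it fixes only a floor and does not settle the order of these two groups: the limit of > 100000 nM in this assay, at which 1 of the 3 values shown sits.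

What the three compounds leave open is whether the effect follows the ring size or the particular ring, since one five-membered and two six-membered rings cannot separate the two. Going by these compounds, it is also open how a simple pyridin-2-yl or phenyl ring, or a small alkyl group such as methyl, would behave on the same sulfonamide nitrogen.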